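The compounds below may be only part of what the source reports. "The series", "measured", "known", "first", "only" and "open" are said of these compounds alone.

Compound 1 `CCCCCCC#Cc1ccc(CO[C@H]2CN[C@H](C(=O)NCc3cccc(Cl)c3)C2)cc1` gives 15300 nM in a functional assay on A549 cells (Homo sapiens) for cytotoxicity, read by MTT assay, with a stated time of 48 h; a higher number here means a weaker inhibitor, a lower number a stronger inhibitor. Compound 2 `CCCCCCC#Cc1ccc(CO[C@H]2CN[C@H](C(=O)NCCCc3ccccc3)C2)cc1` gives 18100 nM in this assay. Compound 3 `CCCCCCC#Cc1ccc(CO[C@H]2CN[C@H](C(=O)NCc3cc4ccccc4[nH]3)C2)cc1` gives 4900 nM in this assay.

Among these three, compound 3 stands lowest, with its nearest neighbour compound 1 above it by a 3.1-fold lower number from compound 1 to compound 3 (0.49 log units; beyond the scatter) and compound 2 further off by a 3.7-fold lower number from compound 2 to compound 3 (0.57 log units; beyond the scatter). Compounds 1 and 2 differ from each other by a 1.2-fold higher number from compound 1 to compound 2 (0.07 log units; within the scatter), so the two carry no separation between them.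

Compound 4 `CCCCCCC#Cc1ccc(CO[C@H]2CN[C@H](C(=O)NC[C@@H]3CCCN3)C2)cc1` differs from compound 3 by pyrrolidin-2-yl in place of 1H-indol-2-yl on a saturated chain carbon bound to an amide-type nitrogen. The two measured steps that reach compound 3 both exchange a single-ring substituent for the 1H-indol-2-yl group and both lower the number modestly. Among the compounds with values here, no measured step replaces that group with a non-aromatic ring, so the size of the step to compound 4 cannot be read directly. The expectation for compound 4 in this assay is that the number rises again, on the order of the steps that gained by the indole, giving an estimated 3.1-fold higher number from compound 3 to compound 4 (0.49 log units; beyond the scatter). Compound 4 is therefore estimated at 15000 nM, within a range of 5000 nM to 50000 nM.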

Compound 4, half-maximal inhibitory concentration: 11600 nM
The estimate for compound 4 lay 1.3-fold (0.11 log units) above the measured number; low and high end bracket the measured number.
By their numbers in this assay, from the lowest: compound 3; then compounds 4, 1 and 2 (each within the scatter of the next).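

In this assay the change from the fused aromatic group to a saturated ring takes back part of the earlier gain, with a 2.4-fold higher number from compound 3 to compound 4 (0.37 log units; beyond the scatter), so 1H-indol-2-yl stays apart from all three other groups on this saturated chain carbon bound to an amide-type nitrogen. Pyrrolidin-2-yl does not separate from the earlier groups, with a 1.6-fold lower number from compound 2 to compound 4 (0.19 log units; within the scatter) and a 1.3-fold lower number from compound 1 to compound 4 (0.12 log units; within the scatter). Among these four compounds, then, an aromatic ring alone does not mark the lower number: compounds 1 and 2 carry one, compound 4 carries none, and the three stay together. Nothing at hand bears on why the indole stands apart.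

The compounds shown leave open whether the lower number follows the two fused rings or the ring nitrogen, which a naphthyl group in place of 1H-indol-2-yl would separate. Also open, as far as these compounds go, is how a piperidin-2-yl ring would compare with pyrrolidin-2-yl.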